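A few compounds are considered here, and "the series" means these few. Any claim that something is new, unique, unknown or untested is made for them only; others in the source may bear on it.

Compound 1, `O=C(Cn1c(=O)oc2cc([N+](=O)[O-])ccc21)Nc1ccccn1`, was tested in an ADME assay on RAW264.7 cells (Mus musculus) for cytotoxicity, read by MTT assay, with a stated time of 72 h, tested at 100 uM (a lower number here means a weaker effect, a higher number a stronger effect of the compound at the concentration tested), where compound 1 gives 47.3%. Among the three compounds measured this is the highest of the numbers, but the nearest neighbour lies within the usual scatter: compound 3, `O=C(Cn1c(=O)oc2cc(Cl)ccc21)Nc1ccccn1`, gives 43.7%, and the step of a number 3.6 percentage points lower from compound 1 to compound 3 (within the scatter) cannot be told apart from repeat-to-repeat variation. The one clear difference comes from compound 2, `O=C(Cn1c(=O)oc2ccccc21)Nc1ccccn1`, which gives 28.4%; the step of a number 18.9 percentage points lower from compound 1 to compound 2 (beyond the scatter) lies beyond the scatter, as does the step of a number 15.3 percentage points higher from compound 2 to compound 3 (beyond the scatter).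

Compound 4, `O=C(Cn1c(=O)oc2cc([N+](=O)[O-])ccc21)NCc1ccccn1`, keeps the nitro-bearing core of compound 1 and differs from it at the amide-type nitrogen: (pyridin-2-yl)methyl in place of pyridin-2-yl on an amide-type nitrogen. None of the three measured steps bears on this change. Every one of them swaps a group on an aromatic carbon of the core, and the amide side of the molecule is the same in compounds 1, 2 and 3. Among the compounds with values here, there is therefore no measured step from which to expect a shift in this assay in either direction, and the plainest expectation is a step of no more than the scatter. On that basis compound 4 is estimated to give 45%, with a range of 30% to 60%, which amounts to an expected step of a number 2.3 percentage points lower from compound 1 to compound 4 (within the scatter).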

Compound 4, a percentage reported as inhibition, at one concentration (the size of the read-out at that concentration, not a potency): 33.4%
Beside the measured number, compound 4's estimate is 11.6 percentage points above it, and the stated range covers the measured number.
By their numbers in this assay, from the lowest: compounds 2 and 4 (each within the scatter of the next); then compounds 3 and 1 (each within the scatter of the next).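

The earlier steps shown here all changed a group on an aromatic carbon of the core and left the amide side untouched, so they could not show whether that side affects the read-out. Compound 4 provides the first test: with the nitro-bearing core kept, (pyridin-2-yl)methyl in place of pyridin-2-yl on the amide-type nitrogen gives a number 13.9 percentage points lower from compound 1 to compound 4 (beyond the scatter) in this assay, so the read-out responds to a change on this nitrogen as well as to changes on the core. Nothing measured here explains why this modest step occurs, and the result records only its direction and size at the one concentration tested.

Within the data shown here, with only one compound carrying (pyridin-2-yl)methyl, it remains open whether the same change would give a similar step on the chloro-bearing core of compound 3 or the unsubstituted core of compound 2. On these data alone, it is also open how the read-out would respond to a longer chain, such as 2-(pyridin-2-yl)ethyl, or to phenyl in place of pyridin-2-yl on the same nitrogen.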